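Swapping an aryl for a butyl on a tripeptide amide

A few compounds are considered here, and "the series" means these few. Any claim that something is new, unique, unknown or untested is made for them only; others in the source may bear on it.

Compound 1 `CCCC[C@H](NC(=O)[C@H](CCCCN)NC(=O)[C@H](CCCNC(=N)N)NC(=O)/C=C/c1ccccc1)C(N)=O` gives 1.26 10^-6 cm/s in an ADME assay for permeability, using PAMPA; on this read-out higher numbers stand for higher permeability and lower numbers for lower permeability.
Compound 2 `CCCC[C@H](NC(=O)[C@H](CCCCN)NC(=O)[C@H](CCCNC(=N)N)NC(=O)c1ccc(/C=C2\SC(=S)N(c3ccc(Cl)cc3)C2=O)cc1)C(N)=O` gives 1.02 10^-6 cm/s in this assay.
Compound 3 `CCCC[C@H](NC(=O)[C@H](CCCCN)NC(=O)[C@H](CCCNC(=N)N)NC(=O)c1ccc(/C=C2\SC(=O)N(c3ccc(C)cc3)C2=O)cc1)C(N)=O` gives 0.66 10^-6 cm/s in this assay.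

In this assay the number of compound 2 sits between those of compound 1 and compound 3, yet both gaps lie within the usual scatter, so the three compounds cannot be told apart. Compound 4 `CCCC[C@H](NC(=O)[C@H](CCCCN)NC(=O)[C@H](CCCNC(=N)N)NC(=O)c1ccc(/C=C2\SC(=S)N(CCCC)C2=O)cc1)C(N)=O` differs from compound 2 in one place: butyl in place of 4-chlorophenyl on an amide-type nitrogen in a ring. Going by the values given here, no measured pair shows a comparable change, so there is nothing to calibrate this step against. The three measured compounds vary widely at this end of the molecule and still coincide within scatter, so no step beyond the scatter is expected in this assay. Compound 4 is therefore estimated at 1 10^-6 cm/s, with a range from 0.4 10^-6 cm/s to 2.5 10^-6 cm/s, a step of a 1.0-fold lower number from compound 2 to compound 4 (0.01 log units; within the scatter) expected to stay within the scatter.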

Compound 4, apparent permeability: 1.61 10^-6 cm/s
The estimate for compound 4 lay 1.6-fold (0.21 log units) below the measured number, and the stated range covers the measured number.
By their numbers in this assay, from the lowest: compounds 3, 2, 1 and 4 (each within the scatter of the next, the first and the last beyond it).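

In this assay, going by these compounds alone, the first single-place change at this nitrogen gives a 1.6-fold higher number from compound 2 to compound 4 (0.20 log units; within the scatter). Here, butyl in place of 4-chlorophenyl removes the aromatic ring and three heavy atoms from this position, and the step still does not leave the scatter. Nothing available bears on why the numbers stay this close.

Going by these compounds, what an amine, a carboxylic acid or a chain longer than butyl would do on this nitrogen remains open. So does whether the same swap would give a comparable step on the core of compound 3 .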